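This account rests on a few compounds, and the source may have more. Where it says the series, first, only, none or still open, it means among the compounds named here.

Measured compounds in an assay on cell membranes for displacement of a labelled ligand from Adrenergic receptor alpha-1 (Rattus norvegicus), tested at 100 nM; a higher number here means a weaker inhibitor, a lower number a stronger inhibitor: compound 1 `COc1cc2nc(N3CCN(C(=O)/C=C/c4ccccc4)CC3)nc(N)c2cc1OC` gives 0.692 nM; compound 2 `COc1cc2nc(N3CCN(C(=O)/C=C/c4ccc(NC(=O)CBr)cc4)CC3)nc(N)c2cc1OC` gives 67.6 nM.

Going by the values given here, compound 2 holds the highest number of the two in this assay; its only neighbour is compound 1, and the step of a 98-fold higher number from compound 1 to compound 2 (1.99 log units; beyond the scatter) is large and well beyond the scatter. That step added a whole ((bromomethyl)carbonyl)amino group to an aromatic carbon of the shared core of compound 1.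

Compound 3 `COC(=O)/C=C/C(=O)Nc1ccc(/C=C/C(=O)N2CCN(c3nc(N)c4cc(OC)c(OC)cc4n3)CC2)cc1` differs from compound 2 in one place: 2-(methoxycarbonyl)ethenyl in place of bromomethyl on a carbonyl carbon. Among the compounds with values here, no measured step changes the group on that carbonyl carbon, so the one step available, from compound 1 to compound 2, bears on it only indirectly, showing that substitution on that aromatic ring costs potency in this assay. With the aromatic carbon still carrying an amide, compound 3 is expected to stay in the region of compound 2, and the step of a 1.5-fold lower number from compound 2 to compound 3 (0.18 log units; within the scatter) is estimated to lie within or near the scatter, direction uncertain. The estimate for compound 3 in this assay is 45 nM, with a range of 8 nM to 250 nM.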

Compound 3, half-maximal inhibitory concentration: 29.5 nM
Compound 3: the middle estimate sits 1.5-fold (0.18 log units) above what was measured; measured number inside the range.
By their numbers in this assay, from the lowest: compound 1; then compound 3; then compound 2.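

In this assay, the group on the carbonyl carbon of the amide affects the result: 2-(methoxycarbonyl)ethenyl in place of bromomethyl gives a 2.3-fold lower number from compound 2 to compound 3 (0.36 log units; beyond the scatter), a modest step beyond the scatter. This recovers only a small part of the loss on the aromatic carbon, since a 43-fold higher number from compound 1 to compound 3 (1.63 log units; beyond the scatter) remains a large step, so both amide-bearing compounds stay far from compound 1. Nothing available explains why these two groups differ.

The compounds shown leave open how a plain amine on that aromatic carbon would compare with the two amides. Also open, going by these compounds, is whether a carboxylic acid in place of the methoxycarbonyl group, or a longer chain on the carbonyl carbon, would bring the number closer to that of compound 1.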